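A few compounds are considered here, and "the series" means these few. Any claim that something is new, unique, unknown or untested is made for them only; others in the source may bear on it.

Three compounds built on the shared core have been run in a functional assay on the whole organism (strain Kunming) with Mus musculus as the target, with a stated time of 0.5 h, at a dose of 300 mg/kg by the intraperitoneal route; on this read-out lower numbers stand for a stronger effect and higher numbers for a weaker effect at the one dose given. Compound 1 `COc1cc(OC)c(OC)cc1/C=C/COC(=O)/C=C/c1c(OC)ccc(OC)c1OC` gives 50% in this assay. Compound 2 `COc1cc(OC)c(OC)cc1/C=C/COC(=O)/C=C/c1cc(OC)c(OC)c(OC)c1OC` gives 0%. Compound 3 `COc1cc(OC)c(OC)cc1/C=C/COC(=O)/C=C/c1ccc(Br)cc1` gives 25%, the second highest of the three numbers; its nearest neighbour is compound 1, whose number is higher by a gap beyond the scatter, and compound 2 lies furthest off, lower by a gap beyond the scatter. Compound 4 `COc1cc(OC)c(OC)cc1/C=C/COC(=O)/C=C/c1ccc(F)cc1` is not yet measured. It differs from compound 3 in one place: fluoro in place of bromo on an aromatic carbon. Among the measured compounds shown here, no measured pair covers this change, so the expected step from compound 3 to compound 4 is small, if anything toward a weaker effect, a number 5 percentage points higher from compound 3 to compound 4 (within the scatter). Compound 4 is estimated at 30%, with a range from 5% to 60%.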

Compound 4, a percentage reported as activity, at one dose (the size of the read-out at that dose, not a potency): 0%
Beside the measured number, compound 4's estimate is 30 percentage points above it, and the stated range ends above it.
By their numbers in this assay, from the lowest: compounds 2 and 4 (each within the scatter of the next); then compound 3; then compound 1.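

In this assay the change from 4-bromophenyl to 4-fluorophenyl brings a number 25 percentage points lower from compound 3 to compound 4 (beyond the scatter) and so a stronger effect at the one dose given. Among the compounds shown here, this first one-place pair shows that the read-out responds to the identity of the halogen on this aromatic carbon, which the earlier compounds could not separate from their other differences. Nothing at hand accounts for the step.

Open, from the compounds shown here alone, is how chloro, an amine or a carboxylic acid at this place would read. Whether the fluoro gain carries over to other substitution patterns also remains unsettled.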